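Working notes: from compound 2 to compound 4

The source may report more compounds than this note shows. Statements on the series, on what has been measured and on what is new or still open speak of the compounds shown alone.

Measured values in a functional assay on HCT-116 cells (Homo sapiens) for inhibition, read by colorimetric assay, with a stated time of 3 days (on this read-out higher numbers stand for weaker inhibition and lower numbers for stronger inhibition), are as follows
- compound 1 `O=C(CCCCCCNC(=O)C(O)(O)C(F)(F)F)Nc1ncc(-c2ccc(Br)cc2)s1` gives 2460 nM
- compound 2 `O=C(CCCCCCNC(=O)C(O)(O)C(F)(F)F)Nc1ccncc1` gives 6670 nM
- compound 3 `CCOc1ccc(-c2cnc(NC(=O)CCCCCCNC(=O)C(O)(O)C(F)(F)F)s2)cc1` gives 4050 nM

Compound 2 at 6670 nM lies within the scatter of compound 3 at 4050 nM on this read-out. Compound 1 at 2460 nM is separated from compound 2 by a gap that lies beyond the scatter, with compound 2 giving the higher number on this read-out. Compound 4 `O=C(CCCCCCNC(=O)C(O)(O)C(F)(F)F)Nc1c(F)cc(F)cc1F` carries 2,4,6-trifluorophenyl in place of pyridin-4-yl on an amide-type nitrogen, counted as 2,4,6-trifluorophenyl in place of pyridin-4-yl on an amide-type nitrogen here. For the measured compounds named here, no measured step covers this exchange directly. The only one, a 1.6-fold higher number from compound 1 to compound 3 (0.22 log units; within the scatter), is ethoxy in place of bromo on an aromatic carbon, and it stays within the scatter. Expected in this assay is a 1.5-fold lower number from compound 2 to compound 4 (0.17 log units; within the scatter), so no step beyond the scatter is anticipated. The estimate for compound 4 is 4500 nM with an expected range from 2000 nM to 10000 nM in this series.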

Compound 4, half-maximal inhibitory concentration: 22200 nM
The estimate for compound 4 lay 4.9-fold (0.69 log units) below the measured number, outside the stated range (above it).
By their numbers in this assay, from the lowest: compounds 1, 3 and 2 (each within the scatter of the next, the first and the last beyond it); then compound 4.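

In this assay, the exchange on the amide-type nitrogen gives a 3.3-fold higher number from compound 2 to compound 4 (0.52 log units; beyond the scatter), a step beyond the scatter, unlike the ethoxy in place of bromo exchange. This position therefore does not treat all six-membered aromatic rings alike: 2,4,6-trifluorophenyl, with no hydrogen-bond acceptor counted, sits apart from pyridin-4-yl, with one. No supporting measurement bears on this step. On these data alone, whether an unsubstituted phenyl on the same nitrogen would stand with compound 2 or with compound 4 remains open, as does whether the three fluorines or the departing ring nitrogen accounts for the step.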